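This account rests on a few compounds, and the source may have more. Where it says the series, first, only, none or still open, it means among the compounds named here.

Working notes on the series, values so far in a functional assay on MDA-MB-435 cells (Homo sapiens) for cytotoxicity, read by MTT assay, with a stated time of 72 h (a higher number here means a weaker inhibitor, a lower number a stronger inhibitor), for:
- compound 1 `NCCCNc1c(C(=O)NCc2ccc(F)cc2)nc(Br)c2cccnc12` with 5000 nM measured
- compound 2 `N[C@H]1CC[C@H](Nc2c(C(=O)NCc3ccc(Oc4ccccc4)cc3)nc(Br)c3cccnc23)CC1` with 4000 nM measured
- compound 3 `N[C@H]1CC[C@H](NC(=O)c2nc(Br)c3cccnc3c2NCc2ccc(F)cc2)CC1` with 6600 nM measured

Compound 1, at 5000 nM in this assay, lies within the usual scatter of both compound 2 and compound 3, so the three values form one group with no ranking among them. Going by the values given here, no pair of measured compounds differs in one place only, so the series offers no direct step to lean on.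

The unmeasured compound 4 `O=C(NCc1ccc(F)cc1)c1nc(Br)c2cccnc2c1NCCO` differs from compound 1 at the end of one chain, the change being (hydroxy in place of aminomethyl on a saturated chain carbon, two bonds along the chain from a nitrogen on an aromatic ring). The same difference reads as 3-aminopropyl to 2-hydroxyethyl. Each measured compound carries a free amino group, and compound 4 would be the first without one, so the data give no direct guide to this change. With compound 1 at 5000 nM as the only close reference, a modest move to a higher number is expected in this assay, possibly no larger than the scatter. The expected step is a 1.8-fold higher number from compound 1 to compound 4 (0.26 log units; within the scatter), an estimate with wide margins. Compound 4 is estimated at 9000 nM, with an expected range from 3000 nM to 25000 nM as a working guess.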

Compound 4, half-maximal inhibitory concentration: > 20000 nM
Compound 4: no number, only a limit (the forecaster's own chance of this, stated with the estimate: 15%); middle value at least 2.2-fold (0.34 log units) from the limit.
By their numbers in this assay, from the lowest: compounds 2, 1 and 3 (each within the scatter of the next). At a limit, above all of these: compound 4.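

For compound 4 the reading in this assay is a limit and not a number: the limit of > 20000 nM in this assay, at which 1 of the 4 values shown sits. Even so, going from 3-aminopropyl to 2-hydroxyethyl on the shared core gives an at least 4.0-fold higher number from compound 1 to compound 4 (0.60 log units; beyond the scatter), the first step in the series that lies beyond the scatter, so this chain end is not indifferent to change, as the earlier values, all within the scatter of each other, could not show. Compounds 1, 2 and 3 all carry a free amino group and compound 4 does not, but with a single step this is an observation on these four compounds and not yet a rule.

On these data alone, the step combines two changes, hydroxy in place of amino and a shorter chain, so what drives it remains open; a 2-aminoethyl or a 3-hydroxypropyl chain on the core of compound 1 would separate the two. As far as these compounds go, the limit also leaves the full size of the step open, and how other chain ends, such as a carboxylic acid or a dimethylamine, would read in this assay is unknown.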